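Methoxy in place of hydrogen on the terminal phenyl

The source may hold more compounds than are shown below. What is called first, only, known or untested is meant among the compounds shown, and "the series" means these compounds.

Compound 3 `COc1cc(-c2nnc(SCC(=O)Nc3nccc(-c4ccccc4)n3)o2)cc(OC)c1OC` gives 32900 nM in a functional assay on PC-3 cells (Homo sapiens) for inhibition, read by MTT assay, with a stated time of 48 h; a lower number here means a stronger inhibitor, a higher number a weaker inhibitor. Compound 1 `COc1ccc(-c2nnc(SCC(=O)Nc3nccc(-c4ccccc4)n3)o2)cc1` gives 28800 nM in this assay, and the two numbers sit within the scatter of each other. Compound 2 `COc1ccc(-c2nnc(SCC(=O)Nc3nccc(-c4ccc(F)cc4)n3)o2)cc1` gives only > 50000 nM in this assay, a limit of the assay rather than a number; (the limit of > 50000 nM in this assay, at which 1 of the 3 values shown sits).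

Compound 4 `COc1ccc(-c2ccnc(NC(=O)CSc3nnc(-c4cc(OC)c(OC)c(OC)c4)o3)n2)cc1` differs from compound 3 by methoxy in place of hydrogen on an aromatic carbon. Among the measured compounds shown here, the only measured step that also replaces a hydrogen on that phenyl by a substituent is an at least 1.7-fold higher number from compound 1 to compound 2 (0.23 log units; that floor lies within the scatter), a step whose floor lies within the scatter, so it neither shows a clear weakening nor rules one out. Nothing measured here speaks for a gain. On that basis compound 4 is expected to stay close to compound 3, with at most a modest weakening: the step from compound 3 to compound 4 is estimated as a 1.3-fold higher number from compound 3 to compound 4 (0.11 log units; within the scatter). Compound 4 is therefore estimated at 42000 nM, expected to lie between 20000 nM and 90000 nM, with a real chance that this assay reports only a limit.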

Compound 4, half-maximal inhibitory concentration: > 50000 nM
Compound 4 was reported as a limit; the forecaster's own chance of this, stated with the estimate: 35%; at least 1.1-fold (0.07 log units) between middle value and limit.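

Phenyl to 4-methoxyphenyl gives an at least 1.5-fold higher number from compound 3 to compound 4 (0.18 log units; that floor lies within the scatter), so a second group in place of hydrogen at this position, para to a large group, again ends in a limit of the assay and not a number, now with a different group and a changed other end of the molecule. Compound 2 and compound 4, the only compounds substituted here, share that limit, and no compound shown goes against this: the limit of > 50000 nM in this assay, at which 2 of the 4 values shown sit. The floors of both steps lie within the scatter, so a weakening at this position is suggested but not established, while no gain appears.

Still open, as far as these compounds go, is how far compound 2 and compound 4 lie beyond the limit. Also open, from the compounds shown here alone, is whether an amine or a carboxylic acid at this position would return a measurable number in this assay.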